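The source may report more compounds than this note shows. Statements on the series, on what has been measured and on what is new or still open speak of the compounds shown alone.

Of the compounds shown here, three built on a shared core have been measured in an in vitro functional assay on cells for agonist activity at Bombesin receptor subtype-3 (Mus musculus), read by luminescence and calcium flux; on this read-out higher numbers stand for an effect only at larger amounts of compound and lower numbers for an effect already at smaller amounts. Compound 1 `CCCCc1cnc(C(C)Cc2ccc(-c3ccccc3C(=O)O)cc2)[nH]1` gives 184 nM in this assay. Compound 2 `COc1cccc(Cc2cnc(CCc3ccc(-c4ccccc4C(=O)O)cc3)[nH]2)c1` gives 79 nM, the second highest of the three numbers; its gap to compound 1 lies beyond the scatter, and its larger gap to compound 3 lies beyond the scatter as well. Compound 3 `CCC(C)(C)Cc1c[nH]c(CCc2ccc(-c3ccccc3C(=O)O)cc2)n1` gives 9.6 nM in this assay. Compound 4 `CC(C)(C)Cc1cnc(CCc2ccc(-c3ccccc3C(=O)O)cc2)[nH]1` has not yet been measured. It differs from compound 2 in one place: tert-butyl in place of 3-methoxyphenyl on a saturated chain carbon bound to an aromatic carbon. The group that enters in compound 4 is of the same kind as the group compound 3 carries in place of it, and compound 3 gives 9.6 nM. On that basis the expected step in this assay is a 5.3-fold lower number from compound 2 to compound 4 (0.72 log units; beyond the scatter), downward and beyond the scatter. Compound 4 is estimated at 15 nM, with a range from 5 nM to 50 nM.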

Compound 4, half-maximal effective concentration: 6.3 nM
Beside the measured number, compound 4's estimate is 2.4-fold (0.38 log units) above it; measured number inside the range.
By their numbers in this assay, from the lowest: compounds 4 and 3 (each within the scatter of the next); then compound 2; then compound 1.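

In this assay, the saturated chain carbon bound to an aromatic carbon proves sensitive to what it carries: tert-butyl in place of 3-methoxyphenyl gives a 13-fold lower number from compound 2 to compound 4 (1.10 log units; beyond the scatter) and so shows that this aromatic ring is not needed here for an effect at small amounts of compound. Compound 3 at 9.6 nM and compound 4 at 6.3 nM lie within the scatter of each other, so the read-out does not separate their two groups. The data at hand hold no measurement that would explain the size of the step.

The compounds shown leave open how much of the step belongs to the ring and how much to its methoxy group, which a plain phenyl or a cyclohexyl at this place would separate. They also leave open how a methyl, a hydroxyl or an amine at this place would fare in this assay against tert-butyl.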